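This account rests on a few compounds, and the source may have more. Where it says the series, first, only, none or still open, it means among the compounds named here.

Measured compounds: compound 1, `CC1=C(C(=O)Nc2ccc(F)cc2)C(c2ccc([N+](=O)[O-])cc2)N=C(SCc2cccc(Cl)c2)N1`; compound 2, `CC1=C(C(=O)Nc2ccc(Br)cc2)C(c2ccc(Cl)cc2Cl)N=C(SCc2ccccc2)N1`.

In a functional assay on the whole organism (artery, strain albino) with Rattus norvegicus as the target, with a stated time of 360 min, at a dose of 10 mg/kg by the oral route (a lower number here means less inhibition, a higher number more inhibition at the dose given (going by the name of the read-out)), compound 1 gives 21.1%. Compound 2 gives 24.2% in this assay. Compound 2 carries the higher of the two numbers, but the gap to compound 1 lies within the scatter, so the two stand level on the evidence at hand. For the measured compounds named here, no pair of measured compounds differs in only one place, so the series offers no step size of its own.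

Compound 3, `CC1=C(C(=O)Nc2ccc(Br)cc2)C(c2ccc(Cl)cc2Cl)N=C(SCc2ccccc2Cl)N1`, is not yet measured. It differs from compound 2 in one place: chloro in place of hydrogen on an aromatic carbon. Cut one bond further out, the benzyl group becomes 2-chlorobenzyl. Going by the values given here, with no comparable step among the measured pairs, the change expected in this assay is small, without a firm direction, and not beyond the scatter. The estimated step from compound 2 to compound 3 is a number 1.8 percentage points higher from compound 2 to compound 3 (within the scatter). For compound 3 the expected value in this assay is 26%, with a range from 10% to 42%.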

Compound 3, a percentage reported as inhibition, in the whole organism at one dose (the size of the read-out at that dose, not a potency): 38.1%
Compound 3: the middle estimate sits 12.1 percentage points below what was measured, within the range that was stated.
By their numbers in this assay, from the lowest: compounds 1 and 2 (each within the scatter of the next); then compound 3.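

The benzylsulfanyl arm gives the series its first readable single-place step: in this assay, chloro in place of hydrogen on an aromatic carbon, ortho to a large group, gives a number 13.9 percentage points higher from compound 2 to compound 3 (beyond the scatter). This position on the benzyl ring is therefore one where a single added chlorine moves the inhibition seen at this oral dose by more than the usual scatter, whereas the earlier pair, differing in several places, could not isolate any position. No measurement at hand bears on why the number rises.

On these data alone, whether this rise is specific to chloro remains open, as a methoxy group, an amine or a carboxylic acid at the same place would show. The compounds shown also leave open whether the step would carry over to a core with other aryl groups, since it rests on one pair.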